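A few compounds are considered here, and "the series" means these few. Any claim that something is new, unique, unknown or untested is made for them only; others in the source may bear on it.

Three compounds of this series carry the shared core with a pendant amine chain and have been measured in an assay on CHO-K1 cells for binding affinity to muscarinic acetylcholine receptor M5 (Homo sapiens); a higher number here means a weaker inhibitor, a lower number a stronger inhibitor. Compound 1 `Cc1ccc2c(c1)C(C(C)c1ccccn1)=C(CCN(C)C)C2` gives 5890 nM. Compound 3 `CN(C)CCC1=C(Cc2ccccn2)c2ccccc2C1` gives 3630 nM. Compound 2 `CC(C1=C(CCN2CCCCC2)Cc2ccccc21)c1ccccn1` gives 2340 nM, the lowest of the three numbers; against compound 1 the gap lies beyond the scatter, against compound 3 it lies within it, so compound 2 and compound 3 are not separable on these data.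

Compound 4 `CC(C1=C(CN(C)C(C)C)Cc2ccccc21)c1ccccn1` has not yet been measured. It differs from compound 2 in one place: isopropyl(methyl)amino in place of (piperidin-1-yl)methyl on a saturated chain carbon bound to a double-bonded ring carbon. For the measured compounds named here, no measured pair isolates a change of this kind, so there is nothing to lean on beyond the values of compound 2 and compound 3, which sit close together despite their differing amine ends. The expectation for the step from compound 2 to compound 4 in this assay is therefore a modest move toward a higher number, estimated as a 1.5-fold higher number from compound 2 to compound 4 (0.17 log units; within the scatter), and not clearly beyond the scatter. For compound 4 the estimated value in this assay is 3500 nM, expected to fall between 1500 nM and 8500 nM.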

Compound 4, inhibition constant: 1120 nM
Beside the measured number, compound 4's estimate is 3.1-fold (0.49 log units) above it, and the stated range ends above it.
By their numbers in this assay, from the lowest: compound 4; then compounds 2, 3 and 1 (each within the scatter of the next, the first and the last beyond it).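

In this assay, for the compounds shown here, this is the first single-place change the series allows to be read: a 2.1-fold lower number from compound 2 to compound 4 (0.32 log units; beyond the scatter). The step is modest but beyond the scatter, so the amine end at this position does register in the read-out. The piperidine ring is also not needed for binding here, since the open isopropyl(methyl)amino group, with no ring and fewer heavy atoms, carries the lower number; no measurement available bears on why the number moves.

Cut one bond further out, the same difference reads 2-(piperidin-1-yl)ethyl to (isopropyl(methyl)amino)methyl, so loss of the ring and shortening of the chain remain entangled. From the compounds shown here alone, a 2-(isopropyl(methyl)amino)ethyl group on the double-bonded ring carbon would pull these two apart, and whether the lower number holds for other open amines, such as diethylamino, stays open.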